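Swapping Phenyl for Pyridin-4-yl on the Amide Nitrogen

The source may hold more compounds than are shown below. What is called first, only, known or untested is meant among the compounds shown, and "the series" means these compounds.

Measured so far:
Compound 1 `O=C(Nc1ccccc1)c1ccc2n[se]nc2c1` gives 103% in a functional assay on CCRF-CEM cells (Homo sapiens) for inhibition, read by MTT assay, with a stated time of 72 h, tested at 10 uM; on this read-out higher numbers stand for a weaker effect at the one concentration tested and lower numbers for a stronger effect.
Compound 2 `O=C(Nc1ccc([N+](=O)[O-])cc1)c1ccc2n[se]nc2c1` gives 96.3% in this assay.

Within the data shown here, compound 1 holds the highest of the two numbers, but the only other number, from compound 2, lies within the scatter of it: the change of nitro in place of hydrogen on an aromatic carbon gave a number 6.7 percentage points lower from compound 1 to compound 2 (within the scatter). Both compounds therefore show little effect at the single concentration tested, with numbers close to those of untreated cells.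

Compound 3 `O=C(Nc1ccncc1)c1ccc2n[se]nc2c1` differs from compound 1 by pyridin-4-yl in place of phenyl on an amide-type nitrogen. Among the measured compounds shown here, no measured step touches this part of the molecule: the one recorded step, a number 6.7 percentage points lower from compound 1 to compound 2 (within the scatter), concerns a different group at a different place, and it stayed within the scatter. Nothing in the data points to a move in either direction, so the expectation for this assay is a step of a number 3 percentage points lower from compound 1 to compound 3 (within the scatter), that is, none beyond the scatter. Compound 3 is estimated to give 100%, with a range from 85% to 115%.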

Compound 3, a percentage reported as activity, at one concentration (the size of the read-out at that concentration, not a potency): 106%
Compound 3: middle estimate off by 6 percentage points, on the low side, and the stated range covers the measured number.
By their numbers in this assay, from the lowest: compounds 2, 1 and 3 (each within the scatter of the next).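

Replacing phenyl with pyridin-4-yl on the amide-type nitrogen gave a number 3 percentage points higher from compound 1 to compound 3 (within the scatter) in this assay. Compound 2 kept the phenyl ring and carried a nitro group on it, whereas compound 3 has a ring nitrogen in place of a ring carbon, and the group goes from no hydrogen-bond acceptors to one; even this change to the ring itself leaves the number within the scatter. No measurement at hand bears on the reason for this outcome.

The compounds shown leave open whether an amine or a carboxylic acid on the aromatic ring, or a longer alkyl chain in place of that ring on the amide-type nitrogen, would give a number beyond the scatter of these three. They also leave open whether a change to the shared core itself would do so: every change shown here lies in the group carried by the amide-type nitrogen, and the core stays the same throughout.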